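The source may hold more compounds than are shown below. What is called first, only, known or untested is meant among the compounds shown, and "the series" means these compounds.

In a functional assay on L1210 cells (Mus musculus) for inhibition (a lower number here means a stronger inhibitor, a higher number a weaker inhibitor), compound 1 (`CS(=O)(=O)OC[C@H]1OC(n2cc(F)c(=O)[nH]c2=O)[C@H](O)[C@@H]1O`), with (methylsulfonyl)oxy on a saturated chain carbon bound to a saturated ring carbon, gives 320 nM while compound 2 (`[N-]=[N+]=NC[C@H]1OC(n2cc(F)c(=O)[nH]c2=O)[C@H](O)[C@@H]1O`), with azido there, gives 170000 nM and compound 3 (`NC[C@H]1OC(n2cc(F)c(=O)[nH]c2=O)[C@H](O)[C@@H]1O`), with amino there, gives 8700 nM as the second highest of the three numbers. Compound 4 (`O=c1[nH]c(=O)n(C2O[C@H](CF)[C@@H](O)[C@H]2O)cc1F`) carries fluoro in place of amino on that same carbon (fluoro in place of amino on a saturated chain carbon bound to a saturated ring carbon). Among the measured compounds shown here, three measured steps bear on this place (a 530-fold higher number from compound 1 to compound 2 (2.73 log units; beyond the scatter); a 27-fold higher number from compound 1 to compound 3 (1.43 log units; beyond the scatter); a 20-fold lower number from compound 2 to compound 3 (1.29 log units; beyond the scatter)), and all three are large and beyond the scatter. They show that a change of group here can move the number a long way in either direction. None of them involves fluoro, however, so they do not say which way this replacement should go. With compound 3 at 8700 nM inside the measured span, the most cautious expectation is a step that stays within the scatter (a 1.4-fold higher number from compound 3 to compound 4 (0.14 log units; within the scatter)), although a large move in either direction remains possible. In this assay the estimate for compound 4 is 12000 nM as the expected middle, with a range from 1500 nM to 80000 nM as its expected span.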

Compound 4, half-maximal inhibitory concentration: 29000 nM
Estimate against measurement, compound 4: 2.4-fold (0.38 log units) below; the measured number falls inside the stated range.
By their numbers in this assay, from the lowest: compound 1; then compound 3; then compound 4; then compound 2.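

In this assay, among the compounds shown here, fluoro on a saturated chain carbon bound to a saturated ring carbon gives a 3.3-fold higher number from compound 3 to compound 4 (0.52 log units; beyond the scatter) and, measured against azido, a 5.9-fold lower number from compound 2 to compound 4 (0.77 log units; beyond the scatter) as its second modest step, so compound 4 places fluoro between amino and azido and shows that this position can also respond by modest amounts, where the earlier steps were all large. The step to (methylsulfonyl)oxy is of another order, with a 91-fold higher number from compound 1 to compound 4 (1.96 log units; beyond the scatter) as a large change, which leaves compound 1 with the lowest number of the four, and amino, fluoro and azido all well above it. Nothing shown gives a measured reason why the four groups fall in this order.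

As far as these compounds go, it remains open whether the low number belongs to (methylsulfonyl)oxy alone or would also appear with another sulfonate ester, such as (phenylsulfonyl)oxy, on the same carbon. It is equally open where chloro, hydroxy or a longer chain such as fluoroethyl would fall among these four compounds, and whether this order would hold on any core other than the one they share.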